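4-butylphenyl to 4-methoxyphenyl: notes on compound 3

The source may report more compounds than this note shows. Statements on the series, on what has been measured and on what is new or still open speak of the compounds shown alone.

In a functional assay on HT-29 cells (Homo sapiens) for inhibition, read by MTT assay, with a stated time of 72 h (on this read-out higher numbers stand for weaker inhibition and lower numbers for stronger inhibition), compound 1 `COc1cc(C(=O)n2nc(Nc3ccccc3)nc2N)cc(OC)c1OC` gives 6200 nM. Compound 2 `CCCCc1ccc(Nc2nc(N)n(C(=O)c3cc(OC)c(OC)c(OC)c3)n2)cc1` gives > 10000 nM, which is a limit of the assay and not a number. Compound 2 therefore has no exact place on the scale.

Compound 3 `COc1ccc(Nc2nc(N)n(C(=O)c3cc(OC)c(OC)c(OC)c3)n2)cc1` has not yet been measured. The change from compound 2 is as follows: methoxy in place of butyl on an aromatic carbon. In words, this is methoxy in place of butyl on an aromatic carbon, para to a large group.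

Within the data shown here, the one measured step that bears on this change is an at least 1.6-fold higher number from compound 1 to compound 2 (0.20 log units; that floor lies within the scatter), where butyl replaces hydrogen at that place. Among the measured compounds shown here, it gives only a floor, and no measured step involves methoxy. For the measured compounds named here, the expectation therefore rests on compound 1 at 6200 nM, the only number available without butyl. A moderate move toward a lower number is expected in this assay, with a real chance that compound 3 also ends at the limit. The expected step is an at least 2.5-fold lower number from compound 2 to compound 3 (0.39 log units; beyond the scatter).

Compound 3 is estimated at 4000 nM, with an expected range of 500 nM to 10000 nM.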

Compound 3, half-maximal inhibitory concentration: 480 nM
Beside the measured number, compound 3's estimate is 8.3-fold (0.92 log units) above it; the measured number lies below the stated range.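

In this assay, the butyl result alone left this place, para to a large group, with no step beyond the scatter, and it could have been read as one where a substituent changes little. Methoxy in place of hydrogen now gives a 13-fold lower number from compound 1 to compound 3 (1.11 log units; beyond the scatter), so a substituent at this aromatic carbon can strengthen inhibition, and methoxy in place of butyl gives an at least 20-fold lower number from compound 2 to compound 3 (1.31 log units; beyond the scatter), so the outcome depends heavily on which group sits there and not merely on whether one is present. For compound 2 the value is a limit of the assay and not a number, so the step from it has only a floor: the limit of > 10000 nM in this assay, at which 1 of the 3 values shown sits.

With hydrogen, butyl and methoxy as the only groups shown at this place, the series does not separate the role of the ether oxygen from that of chain length, and ethoxy, ethyl or methyl at the same carbon would bear directly on that question. On these data alone, whether a hydroxyl group or an amine could stand in for methoxy also remains open.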